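The source may report more compounds than this note shows. Statements on the series, on what has been measured and on what is new or still open speak of the compounds shown alone.

Measured compounds:
- compound 2 `COc1ccc(OCCCON2C(N)=NC(N)=NC23CCOCC3)cc1` — in an assay on isolated protein for inhibition of Dihydrofolate reductase (Homo sapiens), read by spectrophotometry, using NADPH, with stated times of 5 s and 6 min (a higher number here means a weaker inhibitor, a lower number a stronger inhibitor), compound 2 gives 11.1 nM
- compound 1 `NC1=NC2(CCSCC2)N(OCCCOc2ccc(Cl)c(Cl)c2)C(N)=N1` — in this assay compound 1 gives "not determined" (no result reported)
- compound 3 `NC1=NC2(CCSCC2)N(OCCCOc2cc(Cl)c(Cl)cc2Cl)C(N)=N1` — in this assay compound 3 gives "not determined" (no result reported)

Among the measured compounds shown here, compound 2 is the only member of the series with a number in this assay; compound 1 and compound 3, which carry a different core, have no result to set beside it, so there is no measured step and no ranking to speak of. Compound 4 `NC1=NC2(CCOCC2)N(OCCCOc2ccc(Cl)c(Cl)c2)C(N)=N1` keeps the core of compound 2 and differs from it in one place: 3,4-dichlorophenyl in place of 4-methoxyphenyl on an oxygen on a saturated carbon. Compound 1 carries the same 3,4-dichlorophenyl group on a different core, but without a number for it the group's effect cannot be read from the data.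

For the measured compounds named here, with no measured step to lean on, the expectation for compound 4 rests on the single value of compound 2 and on the change itself. Compound 4 is expected to land close to compound 2, with the step from compound 2 to compound 4 estimated at a 1.4-fold lower number from compound 2 to compound 4 (0.14 log units; within the scatter), within or near the usual scatter, leaning if anything toward the stronger side. Compound 4 is therefore estimated at 8 nM, with a range from 3 nM to 30 nM.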

Compound 4, half-maximal inhibitory concentration: 8.23 nM
For compound 4 the middle estimate is 1.0-fold (0.01 log units) below the measured one, within the range that was stated.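

In this assay, among the compounds shown here, placing 3,4-dichlorophenyl in place of 4-methoxyphenyl on an oxygen on a saturated carbon gives a 1.3-fold lower number from compound 2 to compound 4 (0.13 log units; within the scatter), the first measured step. The two aryl groups share a six-membered aromatic ring of carbon only but differ in their substituents, two chlorines against one methoxy, and on this core that exchange does not separate compound 2 from compound 4. This position therefore tolerates both groups in this read-out, at least for these two compounds, and a single pair supports no wider rule. No measured data bear on why the two values stay together.

From the compounds shown here alone, whether a carboxylic acid or an amine on the phenyl ring, or a longer chain in place of the present one, would move the value beyond the scatter stays open. Going by these compounds, the effect of the core also stays open: compound 1 gives "not determined" (no result reported) and compound 3 gives "not determined" (no result reported), so the steps that involve them cannot be read.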